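The compounds below may be only part of what the source reports. "The series", "measured", "known", "first", "only" and "open" are said of these compounds alone.

Compound 1 `COc1cc2c(Oc3ccc(NC(=O)Nc4ccc(C)cc4C)cc3)ccnc2cc1OCCCCCCC(=O)NO`: 5490 nM
Compound 2 `COc1cc2c(Oc3ccc(NC(=O)N/N=C/c4ccccc4)cc3)ccnc2cc1OCCCCCCC(=O)NO`: 3700 nM

In a functional assay on A549 cells (Homo sapiens) for antiproliferative activity, read by MTT assay (a lower number here means a stronger inhibitor, a higher number a weaker inhibitor), compound 2 gives 3700 nM and compound 1 gives 5490 nM, so the two lie within the scatter of each other. Compound 3 `COc1cc2c(Oc3ccc(NC(=O)N/N=C/c4ccccc4F)cc3)ccnc2cc1OCCCCCCC(=O)NO` differs from compound 2 by one small edit: fluoro in place of hydrogen on an aromatic carbon. In words, this is fluoro in place of hydrogen on an aromatic carbon. For the measured compounds named here, the only measured step, a 1.5-fold lower number from compound 1 to compound 2 (0.17 log units; within the scatter), changed a group on an amide-type nitrogen, so it offers only indirect guidance, and no fluoro step has been measured. The expected change is therefore none beyond the scatter, and the estimated step is a 1.1-fold lower number from compound 2 to compound 3 (0.05 log units; within the scatter). For compound 3 the estimated value is 3300 nM, with an expected range of 1400 nM to 7500 nM.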

Compound 3, half-maximal inhibitory concentration: 7780 nM
Compound 3: the middle estimate sits 2.4-fold (0.37 log units) below what was measured; the whole stated range lies below it.
By their numbers in this assay, from the lowest: compounds 2, 1 and 3 (each within the scatter of the next, the first and the last beyond it).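

In this assay, the step from phenyl to 2-fluorophenyl gives a 2.1-fold higher number from compound 2 to compound 3 (0.32 log units; beyond the scatter), so a single fluoro on this aromatic carbon, ortho to a large group, is enough to produce a modest loss of activity. The group on the amide-type nitrogen of compound 3 still leaves it within the scatter of compound 1, at a 1.4-fold higher number from compound 1 to compound 3 (0.15 log units; within the scatter). No measurement available here accounts for the loss. As far as these compounds go, whether a chloro or a methoxy group in the same place would give a similar loss remains open.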